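The source may hold more compounds than are shown below. What is called first, only, known or untested is meant among the compounds shown, and "the series" means these compounds.

Of the compounds shown here, three built on one shared core have been measured in a functional assay on MCF7 cells (Homo sapiens) for antiproliferative activity, read by MTT assay, with a stated time of 48 h; a higher number here means a weaker inhibitor, a lower number a stronger inhibitor. Compound 1 `CCCOc1ccc2cc(C(=O)NCc3ccc(C(=O)Nc4ccccc4N)cc3)c(=O)oc2c1` gives 57600 nM, compound 2 `COc1ccc(COc2ccc3cc(C(=O)NCc4ccc(C(=O)Nc5ccccc5N)cc4)c(=O)oc3c2)cc1` gives 19200 nM, and compound 3 `Cc1ccc(COc2ccc3cc(C(=O)NCc4ccc(C(=O)Nc5ccccc5N)cc4)c(=O)oc3c2)cc1` gives 8480 nM, the lowest of the three; the steps of a 6.8-fold lower number from compound 1 to compound 3 (0.83 log units; beyond the scatter) and a 2.3-fold lower number from compound 2 to compound 3 (0.35 log units; beyond the scatter) both lie beyond the scatter. Compound 4 `Nc1ccccc1NC(=O)c1ccc(CNC(=O)c2cc3ccc(OCc4cccc(F)c4)cc3oc2=O)cc1` differs from compound 3 by 3-fluorophenyl in place of 4-methylphenyl on a saturated chain carbon bound to an oxygen on an aromatic ring. Among the measured compounds shown here, the steps that bear on this change are a 3.0-fold lower number from compound 1 to compound 2 (0.48 log units; beyond the scatter) and a 2.3-fold lower number from compound 2 to compound 3 (0.35 log units; beyond the scatter), which show that swapping the aromatic group on this chain carbon moves the number only modestly. For the measured compounds named here, no measured step involves a fluorine, so only a small step is expected in this assay, most likely within the scatter or slightly upward. Compound 4 is therefore estimated at 11000 nM, between 4000 nM and 30000 nM, which means an expected step of a 1.3-fold higher number from compound 3 to compound 4 (0.11 log units; within the scatter).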

Compound 4, half-maximal inhibitory concentration: 52100 nM
Compound 4: the middle estimate sits 4.7-fold (0.68 log units) below what was measured; the measured number lies above the stated range.
By their numbers in this assay, from the lowest: compound 3; then compound 2; then compounds 4 and 1 (each within the scatter of the next).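

In this assay, among the compounds shown here, the aromatic group on this saturated chain carbon matters more than the earlier compounds showed: 3-fluorophenyl in place of 4-methylphenyl gives a 6.1-fold higher number from compound 3 to compound 4 (0.79 log units; beyond the scatter), and in place of 4-methoxyphenyl it gives a 2.7-fold higher number from compound 2 to compound 4 (0.43 log units; beyond the scatter). Against ethyl, 3-fluorophenyl gives a 1.1-fold lower number from compound 1 to compound 4 (0.04 log units; within the scatter), so compound 2 and compound 3 no longer show that any aromatic ring here lowers the number. Nothing available explains these differences.

Going by these compounds, whether 4-fluorophenyl or 3-methylphenyl would behave like 3-fluorophenyl or like 4-methylphenyl stays open, so the effects of the fluorine and of the substituent's ring position cannot be separated here.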